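Restoring an aryl ketone where a thiophene ring had been

This account rests on a few compounds, and the source may have more. Where it says the series, first, only, none or still open, it means among the compounds named here.

Measured compounds:
compound 1 `O=Cc1ccc(-c2cn3ccnc3c(-c3ccc4ncn(C5CCCCC5)c4c3)n2)cc1` with 47.5%
compound 2 `c1cn2cc(-c3ccsc3)nc(-c3ccc4ncn(C5CCCCC5)c4c3)c2n1` with 14.3%

Both compounds were tested in a functional assay on SR cells (Homo sapiens) for inhibition, read by sulforhodamine B assay, with a stated time of 48 h, tested at 10 uM; on this read-out higher numbers stand for more inhibition at the one concentration tested (going by the name of the read-out) and lower numbers for less inhibition. Compound 2 stands lowest of the two numbers, its nearest neighbour being compound 1, which lies well beyond the scatter above it. Among the compounds with values here, the only measured step is a number 33.2 percentage points lower from compound 1 to compound 2 (beyond the scatter), a large drop when thiophen-3-yl took the place of 4-formylphenyl. Compound 3 `CC(=O)c1ccc(-c2cn3ccnc3c(-c3ccc4ncn(C5CCCCC5)c4c3)n2)cc1` is not yet measured. The change from compound 2 to compound 3 is 4-acetylphenyl in place of thiophen-3-yl on an aromatic carbon. This step runs the earlier one almost in reverse: the thiophen-3-yl leaves again and a six-membered carbon ring carrying a carbonyl-bearing group enters, much as in compound 1. A rise in this assay beyond the scatter is therefore expected, of a size comparable to the earlier drop, though the acetyl group differs from the formyl group of compound 1 and the data hold no direct measurement of that difference. The expected step is a number 30.7 percentage points higher from compound 2 to compound 3 (beyond the scatter). For compound 3 the estimate is 45%, within 25% to 65%.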

Compound 3, a percentage reported as inhibition, at one concentration (the size of the read-out at that concentration, not a potency): 23.6%
Beside the measured number, compound 3's estimate is 21.4 percentage points above it; measured number outside the range, below it.
By their numbers in this assay, from the lowest: compounds 2 and 3 (each within the scatter of the next); then compound 1.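

In this assay, the change at this position gives a number 9.3 percentage points higher from compound 2 to compound 3 (within the scatter), so thiophen-3-yl and 4-acetylphenyl cannot be told apart here, and a six-membered aromatic ring carrying a carbonyl is not enough on its own to reach the level of compound 1. The clearer contrast is on the carbonyl carbon, where methyl in place of hydrogen gives a number 23.9 percentage points lower from compound 1 to compound 3 (beyond the scatter), showing that inhibition at this position can depend on a single small change further out on the ring's substituent. No available data explain why the formyl and acetyl groups differ in this way.

From the compounds shown here alone, it remains open whether a larger group on the carbonyl carbon, as in a propanoyl group, would go with still less inhibition, or whether a carboxylic acid or an aminomethyl group in the same place on the phenyl ring would match compound 1. These three readings, each taken at one concentration, also leave open how potency compares across the compounds, as full dose-response curves would be needed to show that.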